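Replacing a Nitrophenyl Group with a Methylsulfamoylphenyl Group

The source may report more compounds than this note shows. Statements on the series, on what has been measured and on what is new or still open speak of the compounds shown alone.

Compound 1 `CCCS(=O)(=O)Nc1ccc(F)c(C(=O)c2n[nH]c3ncc(-c4cccc(O)c4)cc23)c1F` and compound 2 `CCCS(=O)(=O)Nc1ccc(F)c(C(=O)c2n[nH]c3ncc(-c4cccc([N+](=O)[O-])c4)cc23)c1F` share one core and differ only in the ring that hangs from it. In an assay for binding affinity to dual specificity mitogen-activated protein kinase kinase 4 (Homo sapiens), read by KINOMEscan, tested at 100 nM (on this read-out lower numbers stand for a stronger effect and higher numbers for a weaker effect at the one concentration tested), compound 1 gives 2.2%, while compound 2 gives 15%. Within the data shown here, the one measured step, a number 12.8 percentage points higher from compound 1 to compound 2 (beyond the scatter), shows that changing this ring moves the read-out by a modest amount. Of the two numbers shown, compound 2 stands highest, and its nearest neighbour, compound 1, lies a modest distance below it, beyond the scatter.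

Compound 3 `CCCS(=O)(=O)Nc1ccc(F)c(C(=O)c2n[nH]c3ncc(-c4ccc(S(=O)(=O)NC)cc4)cc23)c1F` carries the next change: 4-(methylsulfamoyl)phenyl in place of 3-nitrophenyl on an aromatic carbon. Among the measured compounds shown here, only the step from compound 1 to compound 2 speaks to this position, and it was modest, so a step of similar size is expected in this assay, more likely downward than upward. Compound 3 is therefore expected to give about 8%, with a range from 1% to 30%, which amounts to an expected step of a number 7 percentage points lower from compound 2 to compound 3 (within the scatter).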

Compound 3, a percentage reported as activity, at one concentration (the size of the read-out at that concentration, not a potency): 1.2%
Estimate against measurement, compound 3: 6.8 percentage points above; low and high end bracket the measured number.
By their numbers in this assay, from the lowest: compounds 3 and 1 (each within the scatter of the next); then compound 2.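

In this assay the read-out with 4-(methylsulfamoyl)phenyl comes out a number 13.8 percentage points lower from compound 2 to compound 3 (beyond the scatter) and so shows that a larger group can sit at this position without weakening the effect seen with 3-nitrophenyl. Among these compounds, the comparison with the hydroxy compound gives a number 1 percentage points lower from compound 1 to compound 3 (within the scatter) and places 3-hydroxyphenyl and 4-(methylsulfamoyl)phenyl level, which leaves 3-nitrophenyl as the one group of the three that stands apart. Nothing available offers a reason for these differences.

The change from compound 2 to compound 3 alters both the group and its place on the phenyl ring, so the two effects cannot be separated, and 4-nitrophenyl or 3-(methylsulfamoyl)phenyl would be needed to pull them apart. On these data alone, how a phenyl ring bearing an amine or a carboxylic acid would behave here also remains open.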